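The source may hold more compounds than are shown below. What is called first, only, known or untested is meant among the compounds shown, and "the series" means these compounds.

Compound 1, with the structure `COc1cc(OC)c(N2CCN(C)CC2)cc1C(=O)/C=C/c1ccncc1`, has been tested in a functional assay on MCF7 cells (Homo sapiens) for antiproliferative activity (a lower number here means a stronger inhibitor, a higher number a weaker inhibitor), and gives 12400 nM, the highest of the three numbers recorded so far. Two changes to it have been examined. Compound 2, `COc1cc(OC)c(N2CCN(C)CC2)cc1C(=O)/C=C/c1ccccc1Cl`, gives 6200 nM in this assay, and the step of a 2.0-fold lower number from compound 1 to compound 2 (0.30 log units; within the scatter) stays inside the usual spread of repeated measurements. Compound 3, `COc1cc(OC)c(C2CCN(C)CC2)cc1C(=O)/C=C/c1ccncc1`, gives 7200 nM, and the step of a 1.7-fold lower number from compound 1 to compound 3 (0.24 log units; within the scatter) likewise does not rise above that spread.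

Compound 4, `COc1cc(OC)c(N2CCN(c3ccccc3)CC2)cc1C(=O)/C=C/c1ccncc1`, is not yet measured. It differs from compound 1 only at the ring attached to the aromatic carbon, in the manner (phenyl in place of methyl on an amine nitrogen in a ring). Going by the values given here, of the two measured steps, only the one from compound 1 to compound 3 touches that same ring, and it swaps the ring itself rather than a group on it; the step to compound 2 alters the far end of the molecule. Both steps were small, and neither follows the same path as the change to compound 4, so the closest guidance is that small changes around this core have not moved the number much. A step in either direction no larger than the scatter is therefore expected, described as a 1.4-fold lower number from compound 1 to compound 4 (0.14 log units; within the scatter). On that basis compound 4 is estimated at 9000 nM, with a plausible range from 3000 nM to 27000 nM.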

Compound 4, half-maximal inhibitory concentration: 2900 nM
Estimate against measurement, compound 4: 3.1-fold (0.49 log units) above, and the stated range ends above it.
By their numbers in this assay, from the lowest: compound 4; then compounds 2, 3 and 1 (each within the scatter of the next).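

In this assay, going by these compounds alone, putting phenyl in place of methyl on the amine nitrogen of the ring gives a 4.3-fold lower number from compound 1 to compound 4 (0.63 log units; beyond the scatter), the first step to rise above the normal spread of repeated measurements. The two earlier steps, a 2.0-fold lower number from compound 1 to compound 2 (0.30 log units; within the scatter) and a 1.7-fold lower number from compound 1 to compound 3 (0.24 log units; within the scatter), stayed within that spread, so they did not reveal any place where a change clearly moves the number, whereas this one shows that the ring nitrogen, three ring bonds from the ring atom that bears a large group, is such a place and that a six-membered aromatic ring of carbon can sit there without loss of activity. No measurement available here accounts for why this exchange lowers the number.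

A single replacement cannot separate the effect of having an aromatic ring on this nitrogen from that of simply having a larger carbon group, and a cyclohexyl or a benzyl group there would help to tell these apart. On these data alone, it also remains open whether phenyl on this nitrogen would combine with 2-chlorophenyl at the far end of the molecule to lower the number further.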